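Swapping the aryl cap on a pyridine alkyne amide

The source may hold more compounds than are shown below. What is called first, only, known or untested is meant among the compounds shown, and "the series" means these compounds.

Measured compounds:
compound 1, `C[C@@H](NC(=O)c1ccc(C#Cc2cccc(F)c2)cn1)C(C)(C)C`, 31.2%
compound 2, `CC1(CCNC(=O)c2ccc(C#Cc3cccc(F)c3)cn2)COC1`, 16.3%

In an ADME assay on HEK293 cells for agonist activity at metabotropic glutamate receptor 5 (Rattus norvegicus), read by fluorescence and calcium flux (a higher number here means a larger maximal response, a lower number a smaller maximal response), compound 1 gives 31.2%, the higher of the two numbers in hand. Within the data shown here, compound 2 sits beneath it: the step of a number 14.9 percentage points lower from compound 1 to compound 2 (beyond the scatter) is the only comparison available, and it concerns the group on the amide-type nitrogen, not the aryl cap at the far end of the alkyne.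

Compound 3, `C[C@@H](NC(=O)c1ccc(C#Cc2ccccn2)cn1)C(C)(C)C`, has not been measured in this assay. It differs from compound 1 in one place: pyridin-2-yl in place of 3-fluorophenyl on a triple-bonded carbon. Among the measured compounds shown here, no measured pair in this set changes the group on the triple-bonded carbon, so the one step on record does not bear on this change and gives no direction for it. The expectation for compound 3 therefore rests on compound 1 alone, with a wide range. Compound 3 is estimated to give 28% in this assay, between 8% and 55%. This expected step, a number 3.2 percentage points lower from compound 1 to compound 3 (within the scatter), would not exceed the scatter.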

Compound 3, largest response reached (reported as efficacy), in percent of the reference or control that the assay uses: 24.2%
For compound 3 the middle estimate is 3.8 percentage points above the measured one, within the range that was stated.
By their numbers in this assay, from the lowest: compounds 2, 3 and 1 (each within the scatter of the next, the first and the last beyond it).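

Among these compounds, at the far end of the alkyne, the change from 3-fluorophenyl to pyridin-2-yl on the triple-bonded carbon gives, in this assay, a number 7 percentage points lower from compound 1 to compound 3 (within the scatter), the first reading of any change at this position. A maximal response of the same order therefore persists when the carbon-only aromatic ring bearing fluorine gives way to a six-membered aromatic ring with 1 hetero atom, even with 1 hydrogen-bond acceptor entering where the leaving group has 0, so at this position the fluorine and the all-carbon ring are not shown to be needed for the response in compound 1. Nothing available accounts for how close the two compounds lie, and no supporting measurement bears on this result.

The compounds shown leave open whether a different group on the triple-bonded carbon, such as 5-fluoropyridin-2-yl, pyrimidin-2-yl or cyclohexyl, would move the response beyond the scatter. They also leave open whether pyridin-2-yl would give a similar reading when paired with the 2-(3-methyloxetan-3-yl)ethyl group on the amide-type nitrogen, or with a longer chain there.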